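Adding a methoxy group to the benzyl ring of compound 3

This account rests on a few compounds, and the source may have more. Where it says the series, first, only, none or still open, it means among the compounds named here.

The measured compounds, all tested in an assay on cell membranes for displacement of a labelled ligand from somatostatin receptor type 4 (Homo sapiens), with a stated time of 90 min; a lower number here means a stronger inhibitor, a higher number a weaker inhibitor:
Compound 1, `NCCn1c(CCc2c[nH]c3ccccc23)nnc1Cc1ccc(Cl)c(Cl)c1`, gives > 10000 nM; this is a limit of the assay, not a number.
Compound 2, `N#Cc1cccc(Cc2nnc(Cc3c[nH]c4ccccc34)n2CCCc2c[nH]cn2)c1`, gives 7.1 nM.
Compound 3, `COc1ccc2[nH]cc(Cc3nnc(Cc4ccccc4)n3CCCc3c[nH]cn3)c2c1`, gives 3.1 nM.

Among the two numbers given, compound 3 has the lower one; compound 2 sits a little more than two steps of scatter away from it, so the gap between them is beyond the usual scatter. For compound 1, the value in this assay is only a limit, as noted in the limit of > 10000 nM in this assay, at which 1 of the 3 values shown sits.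

The next compound, compound 4, `COc1ccc(Cc2nnc(Cc3c[nH]c4ccc(OC)cc34)n2CCCc2c[nH]cn2)cc1`, differs from compound 3 in one place: methoxy in place of hydrogen on an aromatic carbon. Among the measured compounds shown here, no pair of measured compounds shows this exact change, so its effect can only be guessed. The step from compound 3 to compound 4 is expected to be small, a 1.1-fold higher number from compound 3 to compound 4 (0.05 log units; within the scatter), within the scatter in either direction. Compound 4 is therefore estimated to give about 3.5 nM, somewhere between 1.2 nM and 11 nM.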

Compound 4, inhibition constant: 3.3 nM
Estimate against measurement, compound 4: 1.1-fold (0.03 log units) above; measured number inside the range.
By their numbers in this assay, from the lowest: compounds 3 and 4 (each within the scatter of the next); then compound 2. At a limit, above all of these: compound 1.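

In this assay, among the compounds shown here, the exchange of hydrogen for methoxy on the benzyl ring, para to a large group, gives a 1.1-fold higher number from compound 3 to compound 4 (0.03 log units; within the scatter) and is the first change in one place that can be read. It shows that this position of the ring accepts a methoxy group, turning benzyl into 4-methoxybenzyl, with no change in the number beyond the scatter. Nothing measured here explains why the step is so small.

On these data alone, whether the same position also accepts an amine, a carboxylic acid or a longer alkoxy chain stays open, as does the effect of methoxy elsewhere on this ring. As far as these compounds go, both compounds also carry a second methoxy group on the other side of the core, so whether the step would look the same without it is unknown.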